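Nitro exchanged for a nitrile on the aromatic ring

The source may report more compounds than this note shows. Statements on the series, on what has been measured and on what is new or still open speak of the compounds shown alone.

Two measured compounds share one core and differ only in a single group on a six-membered aromatic ring. Compound 1 `Cc1nn(C)c2c1C(c1cccc(O)c1)=NCCN2` carries a hydroxy there, and in a functional assay on the whole organism for positive allosteric modulation, with Rattus norvegicus as the target (a higher number here means that more compound is needed for the effect, a lower number that less compound is needed), compound 1 gives 2.5 mg/kg. Compound 2 `Cc1nn(C)c2c1C(c1cccc([N+](=O)[O-])c1)=NCCN2` carries a nitro instead, and in this assay compound 2 gives 5 mg/kg, the highest of the two numbers. The step of a 2.0-fold higher number from compound 1 to compound 2 (0.30 log units; within the scatter) lies within the scatter, so the two values cannot be told apart.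

Compound 3 `Cc1nn(C)c2c1C(c1cccc(C#N)c1)=NCCN2` has not yet been measured. It differs from compound 2 by cyano in place of nitro on an aromatic carbon. Among the measured compounds shown here, only one measured step bears on this change, the exchange of hydroxy for nitro, and that step was within the scatter. On that basis no movement beyond the scatter is expected for compound 3 in this assay. The expected step in this assay is a 1.3-fold lower number from compound 2 to compound 3 (0.10 log units; within the scatter). Compound 3 is therefore expected to give about 4 mg/kg, with a range from 1.5 mg/kg to 12 mg/kg.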

Compound 3, minimum effective dose: 1.25 mg/kg
For compound 3 the middle estimate is 3.2-fold (0.51 log units) above the measured one, and the stated range ends above it.
By their numbers in this assay, from the lowest: compounds 3, 1 and 2 (each within the scatter of the next, the first and the last beyond it).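

At this place on the aromatic ring, the choice of group can register in this assay: cyano in place of nitro gives a 4.0-fold lower number from compound 2 to compound 3 (0.60 log units; beyond the scatter), the only step among these compounds that lies beyond the scatter. Cyano and hydroxy, by contrast, cannot be told apart, with a 2.0-fold lower number from compound 1 to compound 3 (0.30 log units; within the scatter), so the three compounds do not separate into clear levels, since compound 1 lies within the scatter of both compound 2 and compound 3. Nothing measured here explains why exchanging nitro for cyano shifts the dose.

The compounds shown leave open how an amine, a carboxylic acid or a methoxy group would read at this same place. They also leave open whether the exchange of nitro for cyano would give a similar step on a core other than the shared one.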